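Replacing the benzyl arm on the shared core

This account rests on a few compounds, and the source may have more. Where it says the series, first, only, none or still open, it means among the compounds named here.

Compound 1 `O=C(Nc1ccc(Cl)c(Cl)c1)c1nc[nH]c1C(=O)NCc1ccc(Cl)cc1` gives the lowest number of the three measured compounds in a functional assay on HL-60 cells (Homo sapiens), with a stated time of 2 days (a lower number here means a stronger inhibitor, a higher number a weaker inhibitor), with 16200 nM. Compound 2 `Cc1ccc(CNC(=O)c2[nH]cnc2C(=O)Nc2ccc(Cl)c(Cl)c2)cc1` gives 21400 nM and compound 3 `CC(C)(C)OC(=O)CNC(=O)c1[nH]cnc1C(=O)Nc1ccc(Cl)c(Cl)c1` gives 49800 nM; the step of a 1.3-fold higher number from compound 1 to compound 2 (0.12 log units; within the scatter) is within the scatter, whereas a 3.1-fold higher number from compound 1 to compound 3 (0.49 log units; beyond the scatter) and a 2.3-fold higher number from compound 2 to compound 3 (0.37 log units; beyond the scatter) are modest losses. The unmeasured compound 4 `COC(=O)[C@@H](NC(=O)c1[nH]cnc1C(=O)Nc1ccc(Cl)c(Cl)c1)C(C)C` differs from compound 1 by 1-(methoxycarbonyl)-2-methylpropyl in place of 4-chlorobenzyl on an amide-type nitrogen. The nearest guide is the path from compound 1 to compound 3, because a 3.1-fold higher number from compound 1 to compound 3 (0.49 log units; beyond the scatter) likewise put an ester-bearing chain in place of an aryl-bearing chain on that nitrogen, so a weakening of similar size is expected in this assay. Compound 4 is accordingly expected to give 40000 nM, within 15000 nM to 110000 nM, an expected step of a 2.5-fold higher number from compound 1 to compound 4 (0.39 log units; beyond the scatter).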

Compound 4, half-maximal inhibitory concentration: > 62500 nM
Compound 4: only a limit was reported (the forecaster's own chance of this, stated with the estimate: 10%); at least 1.5-fold (0.19 log units) between middle value and limit.
By their numbers in this assay, from the lowest: compounds 1 and 2 (each within the scatter of the next); then compound 3. At a limit, above all of these: compound 4.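

In this assay, compound 4 gives only a limit, not a number: the limit of > 62500 nM in this assay, at which 1 of the 4 values shown sits. A second ester-bearing chain, here with no ring and a defined stereocentre, again falls behind the benzyl arms, with an at least 3.8-fold higher number from compound 1 to compound 4 (0.58 log units; beyond the scatter) and an at least 2.9-fold higher number from compound 2 to compound 4 (0.46 log units; beyond the scatter). Against the (tert-butoxycarbonyl)methyl arm the reading is an at least 1.2-fold higher number from compound 3 to compound 4 (0.09 log units; that floor lies within the scatter), so the two ester-bearing chains cannot be put in order.

The compounds shown leave open whether a free carboxylic acid in place of the ester would behave the same way. They also leave open what the opposite stereocentre would give.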